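Adding a third methoxy to compound 3

This account rests on a few compounds, and the source may have more. Where it says the series, first, only, none or still open, it means among the compounds named here.

Of the compounds shown here, three sharing one core have been tested so far. Compound 1 `COc1ccc(CNc2ncnc3c2ncn3C2CCCCO2)c(OC)c1` gives > 25000 nM in an ADME assay on MCF7 cells (Homo sapiens) for cytotoxicity, with a stated time of 72 h (on this read-out higher numbers stand for weaker inhibition and lower numbers for stronger inhibition), and this is a limit, not a number. Compound 2 `COc1ccc(OC)c(CNc2ncnc3c2ncn3C2CCCCO2)c1` gives a measured number of 25400 nM in this assay on the same cells. Compound 3 `COc1ccc(CNc2ncnc3c2ncn3C2CCCCO2)cc1OC` stands only at the limit > 100000 nM and so has no number of its own.

Compound 4 `COc1cc(OC)c(OC)cc1CNc1ncnc2c1ncn2C1CCCCO1` differs from compound 3 by a single change methoxy in place of hydrogen on an aromatic carbon that puts methoxy in place of hydrogen on an aromatic carbon. For the measured compounds named here, no measured step between these compounds shows what such a change does. Compound 2 at 25400 nM shows that a number can be reached in this assay and this is the only ground for expecting a modest move toward stronger inhibition. The estimated step of an at least 2.5-fold lower number from compound 3 to compound 4 (0.39 log units; beyond the scatter) is uncertain as it starts from a limit. Another result reported only as a limit is quite possible. For compound 4 the estimated value is 40000 nM with an expected range from 15000 nM to 100000 nM in the coming measurement.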

Compound 4, half-maximal inhibitory concentration: > 100000 nM
Compound 4 ended at the assay's limit; the forecaster's own chance of this, stated with the estimate: 55%; at least 2.5-fold (0.39 log units) between middle value and limit.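

With the added methoxy on the aromatic carbon ortho to a large group, compound 4 is reported in this assay only as a limit, > 100000 nM. Compared with the measured number of compound 2, the record shows an at least 3.9-fold higher number from compound 2 to compound 4 (0.59 log units; beyond the scatter), so this third methoxy does not bring the series back to a number within the range of the assay. The steps to compound 4 from compound 3 and from compound 1 cannot be read, because in each pair both values are limits: the limit of > 100000 nM in this assay, at which 2 of the 4 values shown sit.

As far as these compounds go, whether the methoxy shifts the true value at all relative to compound 3 stays open. Also open, from the compounds shown here alone, is how an amine, a carboxylic acid or a longer chain on this same aromatic carbon would read in this assay.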